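The compounds below may be only part of what the source reports. "The series", "measured", "known", "first", "only" and "open" are said of these compounds alone.

Values in an assay on isolated protein for inhibition of phosphodiesterase 4A (Sus scrofa); a lower number here means a stronger inhibitor, a higher number a weaker inhibitor:

compound 1 `COc1ccc(C(=O)Nc2c(F)cccc2Cl)cc1OC1CCCC1`: 240 nM
compound 2 `COc1ccc(C(=O)Nc2c(C)cccc2Cl)cc1OC1CCCC1`: 100 nM
compound 3 `COc1ccc(C(=O)NN2C(Cl)=NC=CC2Cl)cc1OC1CCCC1`: 400 nM

Compound 3 sits at the high end of these three numbers. Against compound 1 the step is a 1.7-fold higher number from compound 1 to compound 3 (0.22 log units; within the scatter), so the two are not separable; against compound 2 it is a 4.0-fold higher number from compound 2 to compound 3 (0.60 log units; beyond the scatter), a modest but real gap. Both steps concern the group on the amide-type nitrogen: exchanging an aromatic carbon-only ring for the six-membered non-aromatic ring with 2 hetero atoms raised the number in each case, more so from compound 2.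

Compound 4 `COc1ccc(C(=O)Nc2c(C)nsc2C#N)cc1OC1CCCC1` changes that same position again: a group of 8 heavy atoms (5 carbon, 2 nitrogen, 1 sulfur; one five-membered aromatic ring with 2 hetero atoms) in place of a group of 8 heavy atoms (4 carbon, 2 nitrogen, 2 chlorine; one six-membered non-aromatic ring with 2 hetero atoms), on an amide-type nitrogen. Within the data shown here, the entering group is aromatic, as in compounds 1 and 2, but it is a five-membered ring with 2 hetero atoms carrying a nitrile and a methyl, for which no measured pair exists. Among the measured compounds shown here, the two steps back from compound 3 to the aromatic rings are the only guide; they point toward a lower number, of modest size. A step of about a 2.0-fold lower number from compound 3 to compound 4 (0.30 log units; within the scatter) is therefore expected, with wide uncertainty in this assay. Compound 4 is estimated at 200 nM, in the range 60 nM to 650 nM.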

Compound 4, half-maximal inhibitory concentration: 200 nM
Estimate against measurement, compound 4: no gap at the digits printed, within the range that was stated.
By their numbers in this assay, from the lowest: compounds 2, 4, 1 and 3 (each within the scatter of the next, the first and the last beyond it).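

In this assay, the group on the amide-type nitrogen now includes a five-membered aromatic ring with 2 hetero atoms, and 5-cyano-3-methyl-1,2-thiazol-4-yl cannot be separated from either six-membered aromatic group (a 2.0-fold higher number from compound 2 to compound 4 (0.30 log units; within the scatter); a 1.2-fold lower number from compound 1 to compound 4 (0.08 log units; within the scatter)). Compound 4 also cannot be separated from the non-aromatic group of compound 3 (a 2.0-fold lower number from compound 3 to compound 4 (0.30 log units; within the scatter)), whereas compound 2 stands clear of compound 3, so compound 4 lies within the scatter of both ends of the series. Each of these steps alters the ring and its substituents together, so the values show that this position accepts the whole group without assigning any share of the result to ring size, the hetero atoms, the nitrile or the methyl.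

From the compounds shown here alone, it remains open how a 1,2-thiazol-4-yl group carrying an amine or a carboxylic acid in place of the nitrile would read in this assay. Going by these compounds, a piperidine on the amide-type nitrogen, or an ethyl chain in place of the methyl, is equally open.

No measurement offered here accounts for these values.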